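Cinnamide series: carboxy for bromo on the aryl ring

The compounds below may be only part of what the source reports. "The series", "measured", "known", "first", "only" and "open" are said of these compounds alone.

Measured compounds:
compound 1 `CC(C)(C)c1ccc(/C=C/C(=O)Nc2ccc3c(c2)CCCC3)cc1`: 61 nM
compound 2 `CC(C)(C)c1ccc(/C=C/C(=O)Nc2ccc3c(c2)OCCO3)c(Br)c1`: 60 nM

In a functional assay on CHO cells for inhibition of transient receptor potential cation channel subfamily V member 1 (Homo sapiens) (on this read-out lower numbers stand for stronger inhibition and higher numbers for weaker inhibition), compound 1 gives 61 nM. In this assay compound 2 gives 60 nM. Of the two numbers that of compound 2 is the lower, but the two lie within the usual scatter of each other, so no order between compound 1 and compound 2 can be read from them.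

Compound 3 `CC(C)(C)c1ccc(/C=C/C(=O)Nc2ccc3c(c2)OCCO3)c(C(=O)O)c1` has not been measured. It differs from compound 2 in one place: carboxy in place of bromo on an aromatic carbon. For the measured compounds named here, no measured pair in the set shows this change, so its size and direction rest on no measured step. The step from compound 2 to compound 3 is expected to go toward a higher number, beyond the scatter, by a 6.7-fold higher number from compound 2 to compound 3 (0.82 log units; beyond the scatter). Compound 3 is accordingly estimated at 400 nM, with a range from 80 nM to 3000 nM.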

Compound 3, half-maximal inhibitory concentration: > 4000 nM
Compound 3: no number, only a limit (the forecaster's own chance of this, stated with the estimate: 15%); middle value at least 10-fold (1.00 log units) away from the limit.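

Carboxy in place of bromo on this aromatic carbon, ortho to a large group and meta to a tert-butyl group, gives in this assay an at least 66-fold higher number from compound 2 to compound 3 (1.82 log units; beyond the scatter). For the compounds shown here, this is the first step, and it shows that inhibition at this position depends strongly on the group carried there, which compound 1 and compound 2 could not show. Compound 3 is reported only as a limit, and the size of the step rests on that limit: the limit of > 4000 nM in this assay, at which 1 of the 3 values shown sits.

As far as these compounds go, it remains open whether a methyl ester, a primary carboxamide or a hydroxymethyl group on the same carbon would retain inhibition or behave like carboxy. Going by these compounds alone, also open is how bromo compares with plain hydrogen here, as no single-place step links compound 1 to compound 2.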